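This account rests on a few compounds, and the source may have more. Where it says the series, first, only, none or still open, it means among the compounds named here.

Measured so far:
- compound 1, `N#Cc1cnc(NCc2cnccc2C(F)(F)F)cc1NC[C@H]1CC[C@@H](O)CC1`: 58 nM in an assay on isolated protein for inhibition of protein kinase C theta type (Homo sapiens), read by TR-FRET, with a stated time of 2 h; on this read-out higher numbers stand for weaker inhibition and lower numbers for stronger inhibition
- compound 2, `N#Cc1cnc(NCc2cnccc2C(F)(F)F)cc1N[C@H]1CC[C@@H](n2cncn2)CC1`: in this assay compound 2 gives 100 nM
- compound 3, `CC1(C)C[C@H](Nc2cc(NCc3cnccc3C(F)(F)F)ncc2C#N)CC(C)(C)[C@H]1O`: in this assay compound 3 gives 20 nM

Compound 1 holds the second highest of the three numbers. Its nearest neighbour is compound 2, whose value lies within the scatter of that of compound 1, so no order between those two can be read. Compound 3 stands further off, beyond the scatter, with the lower number of the three.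

The next compound is compound 4, `CC1(C)C[C@@H](Nc2cc(NCc3cnccc3C(F)(F)F)ncc2C#N)CC[C@@H]1O`. It differs from compound 1 as follows:

4-hydroxy-3,3-dimethylcyclohexyl in place of (4-hydroxycyclohexyl)methyl on a nitrogen on an aromatic ring

The change brings compound 4 close to compound 3, which also carries the hydroxyl-bearing ring directly on the nitrogen, though compound 3 carries an additional pair of methyls on that ring. Within the data shown here, no step between measured compounds tracks this change in isolation.

The expectation is that compound 4 moves somewhat towards compound 3, a modest step downwards in this assay, about a 1.8-fold lower number from compound 1 to compound 4 (0.26 log units; within the scatter), which may or may not clear the scatter. Compound 4 is therefore estimated at 32 nM in this assay. The expected range for compound 4 is 12 nM to 90 nM.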

Compound 4, half-maximal inhibitory concentration: 120 nM
Beside the measured number, compound 4's estimate is 3.8-fold (0.57 log units) below it; measured number outside the range, above it.
By their numbers in this assay, from the lowest: compound 3; then compounds 1, 2 and 4 (each within the scatter of the next, the first and the last beyond it).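

In this assay, among these compounds, 4-hydroxy-3,3-dimethylcyclohexyl in place of (4-hydroxycyclohexyl)methyl on a nitrogen on an aromatic ring gives a 2.1-fold higher number from compound 1 to compound 4 (0.32 log units; beyond the scatter), the only step at this position that can be read so far, and it is modest. Carrying a hydroxyl-bearing ring directly on the nitrogen is therefore not enough on its own to give a low number: compound 3 gives 20 nM and compound 4 gives 120 nM, although the two rings differ by a further pair of methyls. Nothing measured on these compounds speaks to the cause of this step.

The step joins two changes in one, the loss of the methylene link and the gain of the pair of methyls, and the compounds shown do not separate them; a plain 4-hydroxycyclohexyl directly on the nitrogen would do so. Also open is whether an amine or a carboxylic acid in place of the hydroxyl would hold up on either ring, with compound 2 as the only compound shown without that hydroxyl.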